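The source may report more compounds than this note shows. Statements on the series, on what has been measured and on what is new or still open speak of the compounds shown alone.

Measured compounds:
compound 1 `OB1OCc2ccc(-n3cccc3)cc21`: in an ADME assay on L929 cells (Mus musculus) for cytotoxicity, read by resazurin assay, with a stated time of 72 h (a higher number here means a weaker inhibitor, a lower number a stronger inhibitor), compound 1 gives > 10 ug/mL, which is a limit of the assay and not a number.
compound 2 `OB1OCc2ccc(-n3cccc3Sc3ccc(Cl)c(Cl)c3)cc21`: in this assay compound 2 gives > 10 ug/mL, again a limit rather than a number.
compound 3 `O=C(c1ccn(-c2ccc3c(c2)B(O)OC3)c1)c1ccccc1Cl`: in this assay compound 3 gives > 10 ug/mL, also a limit.

Compound 3 therefore stands exactly where the other two stand, at the limit of > 10 ug/mL in this assay, at which 3 of the 3 values shown sit. Among the compounds with values here, no two of the measured compounds differ in a single place, so no measured step is available, and the three values together show only that none of them reached a number in this assay.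

Compound 4 `Nc1ccc(C(=O)c2ccn(-c3ccc4c(c3)B(O)OC4)c2)cc1` has not yet been measured. It differs from compound 3 in one place: 4-aminophenyl in place of 2-chlorophenyl on a carbonyl carbon.

Because the value of compound 3 is > 10 ug/mL, a limit, there is no measured number from which a shift could be read. The step that the limit leaves unreadable from compound 3 to compound 4 is expected to be none beyond the usual scatter in this assay.

Compound 4 is accordingly estimated at 20 ug/mL in this assay, with a range from 8 ug/mL to 60 ug/mL, and the most likely outcome is that the assay again reports only its limit rather than a number for compound 4.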

Compound 4, half-maximal inhibitory concentration: 3.9 ug/mL
Compound 4: the middle estimate sits 5.1-fold (0.71 log units) above what was measured; measured number below the stated range.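

In this assay, the group on the carbonyl carbon proves able to move the read-out: 4-aminophenyl in place of 2-chlorophenyl gives an at least 2.5-fold lower number from compound 3 to compound 4 (0.40 log units; beyond the scatter), a step beyond the scatter towards stronger inhibition of the cells. As far as these compounds go, compound 1, compound 2 and compound 3 could not show this, as none of them gave a number, and compound 4 is the only one of the four that stands off the shared limit: the limit of > 10 ug/mL in this assay, at which 3 of the 4 values shown sit. With one end of the step at that limit, its true size stays unknown and only its direction and minimum are established, so this single change marks the carbonyl substituent as a place where the read-out can respond, without saying how far.

The step swaps two features at once, the chlorine leaving and the amine entering, so the compounds shown cannot separate the loss of one from the gain of the other. An unsubstituted phenyl on the same carbonyl carbon would divide the two, and an acetamide or a carboxylic acid in place of the amine would show whether the amine itself is needed.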